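Aryl hydrazone series: removing both bromines from compound 2

The source may hold more compounds than are shown below. What is called first, only, known or untested is meant among the compounds shown, and "the series" means these compounds.

Measured so far:
- compound 1, `CN(C)CCn1cnnc1-c1cc(Oc2ccc(NC(=O)N/N=C/c3ccc(O)c(Br)c3)cc2F)ccn1`: 1370 nM
- compound 2, `CN(C)CCn1cnnc1-c1cc(Oc2ccc(NC(=O)N/N=C/c3cc(Br)c(O)c(Br)c3)cc2F)ccn1`: > 100000 nM (a limit of the assay, no number)
- compound 3, `COc1ccc(/C=N/NC(=O)Nc2ccc(Oc3ccnc(-c4nncn4CCN(C)C)c3)c(F)c2)cc1O`: not yet measured

Compound 2 sits at the limit of a functional assay on A549 cells (Homo sapiens) for cytotoxicity, read by MTT assay, with a stated time of 72 h (on this read-out lower numbers stand for stronger inhibition and higher numbers for weaker inhibition), and is the weaker of the two measured compounds; (the limit of > 100000 nM in this assay, at which 1 of the 2 values shown sits), so its true value is not known. Compound 3 differs from compound 2 in one place: 3-hydroxy-4-methoxyphenyl in place of 3,5-dibromo-4-hydroxyphenyl on a carbon with a double bond to nitrogen. Among the compounds with values here, the one measured step that bears on this change is an at least 72-fold higher number from compound 1 to compound 2 (1.86 log units; beyond the scatter), which shows that adding bromine on this ring cost a large amount of activity. Within the data shown here, compound 3 carries no bromine at all, so a return toward the range of compound 1 is expected, although the methoxy group has no precedent among the measured compounds and the hydroxy group no longer sits where it does in compound 1. The step expected is an at least 33-fold lower number from compound 2 to compound 3 (1.52 log units; beyond the scatter). For compound 3 in this assay the expected value is 3000 nM, with a range of 500 nM to 30000 nM.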

Compound 3, half-maximal inhibitory concentration: > 100000 nM
Compound 3 was reported as a limit; the forecaster's own chance of this, stated with the estimate: 20%; at least 33-fold (1.52 log units) between middle value and limit.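

Compound 3 gives > 100000 nM in this assay, and this is a limit of the assay, not a number. Losing bromine from this ring is therefore not enough to bring back a readable value, as the exchange of 3-bromo-4-hydroxyphenyl for 3-hydroxy-4-methoxyphenyl on the carbon with a double bond to nitrogen gives an at least 72-fold higher number from compound 1 to compound 3 (1.86 log units; beyond the scatter). The step between the two compounds at the limit cannot be read, so no order can be given for the 3,5-dibromo-4-hydroxyphenyl and 3-hydroxy-4-methoxyphenyl groups: the limit of > 100000 nM in this assay, at which 2 of the 3 values shown sit.

The 3-hydroxy-4-methoxyphenyl group differs from the 3-bromo-4-hydroxyphenyl group of compound 1 in more than one feature, so the compounds shown do not tell whether the methoxy group, the place of the hydroxy group or the missing bromine goes with the loss. Also open, from the compounds shown here alone, is whether this position keeps a readable value with a 3-chloro-4-hydroxyphenyl group or a plain 4-hydroxyphenyl group.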